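Methoxy on the Phenyl Ring and Cell Toxicity

This account rests on a few compounds, and the source may have more. Where it says the series, first, only, none or still open, it means among the compounds named here.

Compound 1 `Cc1ncc([N+](=O)[O-])n1CC(O)CN1CCN(c2ccccc2)CC1` and compound 3 `Cc1nc([N+](=O)[O-])cn1CC(O)CSC(=S)N1CCN(c2ccccc2)CC1` were both tested in a toxicity assay on HeLa cells (Homo sapiens) for cytotoxicity, read by MTT assay, with a stated time of 24 h (a higher number here means a weaker inhibitor, a lower number a stronger inhibitor), and the difference between these two cores is not broken down here. In this assay compound 1 gives > 5000000 nM, which is a limit of the assay and not a number. Compound 3 likewise gives only a limit of the assay in this assay, namely > 5000000 nM. Compound 2 `COc1ccccc1N1CCN(CC(O)Cn2c([N+](=O)[O-])cnc2C)CC1` differs from compound 1 by methoxy in place of hydrogen on an aromatic carbon, and in this assay compound 2 gives 4390000 nM, so that the step is an at least 1.1-fold lower number from compound 1 to compound 2 (0.05 log units; that floor lies within the scatter). Because (the limit of > 5000000 nM in this assay, at which 2 of the 3 values shown sit), the starting value of compound 1 is itself a limit of the assay, so the size of that step is open-ended. Compound 4 `COc1ccccc1N1CCN(C(=S)SCC(O)Cn2cc([N+](=O)[O-])nc2C)CC1` is not yet measured and carries methoxy in place of hydrogen on an aromatic carbon on the core of compound 3, the same change that separates compound 1 from compound 2. For compound 4 the expected step is an at least 1.1-fold lower number from compound 3 to compound 4 (0.04 log units; that floor lies within the scatter), which rests on an at least 1.1-fold lower number from compound 1 to compound 2 (0.05 log units; that floor lies within the scatter) and on the limit given by compound 3. Compound 4 is therefore estimated at 4500000 nM in this assay, with a likely range from 2000000 nM to 10000000 nM.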

Compound 4, half-maximal inhibitory concentration: > 5000000 nM
Compound 4 gave a limit, no number; the forecaster's own chance of this, stated with the estimate: 60%; middle value at least 1.1-fold (0.04 log units) from the limit.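

In this assay, compound 4 gives > 5000000 nM, which is a limit of the assay and not a number. Among these compounds, no step from compound 3 to compound 4 can be read, because both compounds give only a limit: the limit of > 5000000 nM in this assay, at which 3 of the 4 values shown sit. The compounds shown leave open how far the change from phenyl to 2-methoxyphenyl moves the number on either core.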